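Working notes: ethoxy to methoxymethyl in the series

A few compounds are considered here, and "the series" means these few. Any claim that something is new, unique, unknown or untested is made for them only; others in the source may bear on it.

Measured so far:
- compound 1 `CCS(=O)(=O)c1ccc(COC[C@@H]2C[C@@H]2C2CCN(c3nc(C(C)C)no3)CC2)c(F)c1`: 127000 nM
- compound 2 `CCOc1cnc(N2CCC([C@H]3C[C@H]3COCc3ccc(S(C)(=O)=O)c(F)c3)CC2)nc1`: 101000 nM

Both numbers come from a physicochemical assay for solubility, in simulated intestinal fluid, measured as kinetic solubility, at pH 6.5 (on this read-out lower numbers stand for lower solubility and higher numbers for higher solubility), and they sit close together. For the measured compounds named here, compound 1 gives 127000 nM and compound 2 gives 101000 nM in this read-out, so compound 2 stands within the scatter of the only other measured compound.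

Compound 3 `COCc1cnc(N2CCC([C@H]3C[C@H]3COCc3ccc(S(C)(=O)=O)c(F)c3)CC2)nc1` has not yet been measured. It differs from compound 2 in one place: methoxymethyl in place of ethoxy on an aromatic carbon. In words, methoxymethyl takes the place of ethoxy on an aromatic carbon, and the two compounds have the same atoms, joined differently.

Going by the values given here, no measured pair isolates this change, so the data offer no direct precedent. The expectation for this assay is therefore no step beyond the scatter, with no firm direction. Among the compounds with values here, the only support is that compound 1 at 127000 nM and compound 2 at 101000 nM stay close despite their different structures. The estimated step is a 1.1-fold higher number from compound 2 to compound 3 (0.04 log units; within the scatter) and it is expected to stay within the scatter. For compound 3 the expected value is 110000 nM with an estimated range from 60000 nM to 180000 nM in this read-out.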

Compound 3, solubility: 155000 nM
Estimate against measurement, compound 3: 1.4-fold (0.15 log units) below, and the stated range covers the measured number.
By their numbers in this assay, from the lowest: compounds 2, 1 and 3 (each within the scatter of the next).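

Working notes, reading the step: in this assay, compounds 2 and 3 form the first pair in the series that differs in one place, and the swap of 5-ethoxypyrimidin-2-yl to 5-(methoxymethyl)pyrimidin-2-yl gives a 1.5-fold higher number from compound 2 to compound 3 (0.19 log units; within the scatter). So at this position, on an aromatic carbon para to a large group, this read-out does not separate two groups that have the same atoms joined differently, and this pair gives the series its first direct precedent for the change. No supporting data bear on why the step has this size, and a single pair says nothing about other positions.

The compounds shown leave open whether an amine, a carboxylic acid or a longer chain on this aromatic carbon would give a step beyond the scatter, which would show how much room this position has in this assay. They also leave open whether methoxymethyl in place of ethoxy reads the same way on another core, such as the core of compound 1, or in any other read-out.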